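Swapping Piperidinyl for Bromo on Compound 1

The source may report more compounds than this note shows. Statements on the series, on what has been measured and on what is new or still open speak of the compounds shown alone.

Compound 1 `N[C@H]1CC[C@H](Nc2c(C(=O)NCc3ccc(F)cc3)nc(N3CCCCC3)c3cccnc23)CC1` carries a (4-aminocyclohexyl)amino group and a piperidin-1-yl group on its shared core. In a functional assay on HT-29 cells (Homo sapiens) for cytotoxicity, read by MTT assay, with a stated time of 72 h (a higher number here means a weaker inhibitor, a lower number a stronger inhibitor), compound 1 gives "not determined" (no result reported), so no number fixes where it stands. Compound 2 `CNCCCNc1c(C(=O)NCc2ccc(F)cc2)nc(Br)c2cccnc12`, a bromo analogue with a different amine chain, is known only as a limit: in this assay compound 2 gives > 10000 nM. Compound 3 `N[C@H]1CC[C@H](Nc2c(C(=O)NCc3ccc(F)cc3)nc(Br)c3cccnc23)CC1` differs from compound 1 by bromo in place of piperidin-1-yl on an aromatic carbon. Going by the values given here, no measured step covers this change; since the one bromo compound sits at the limit of > 10000 nM in this assay, at which 1 of the 2 values shown sits, a step toward weaker inhibition beyond the scatter, or again only a limit, is expected in this assay. Compound 3 is estimated at 8000 nM, between 1500 nM and 30000 nM.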

Compound 3, half-maximal inhibitory concentration: < 1000 nM
Compound 3 was reported as a limit; the forecaster's own chance of this, stated with the estimate: 55%; middle value at least 8.0-fold (0.90 log units) away from the limit.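

With bromo kept in place, 4-aminocyclohexyl in place of 3-(methylamino)propyl on a nitrogen on an aromatic ring gives an at least 10-fold lower number from compound 2 to compound 3 (1.00 log units; beyond the scatter) in this assay. A bromo compound therefore need not be weak here, and the single earlier bromo result did not speak for bromo alone. The value of compound 3 is itself a limit: the limit of < 1000 nM in this assay, at which 1 of the 3 values shown sits.

The step from piperidin-1-yl to bromo cannot be read: compound 1 has no number. From the compounds shown here alone, whether a chloro or morpholin-4-yl group at this carbon, or a longer chain on that nitrogen, would match compound 3 stays open.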